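The source may report more compounds than this note shows. Statements on the series, on what has been measured and on what is new or still open speak of the compounds shown alone.

Measured so far in an assay on isolated protein for inhibition of protein kinase C theta type (Homo sapiens), read by TR-FRET, with a stated time of 2 h; on this read-out lower numbers stand for stronger inhibition and higher numbers for weaker inhibition:
compound 1, `CO[C@H]1CC[C@@H](Nc2cc(NCc3cnccc3C(F)(F)F)ncc2C#N)CC1`, 58 nM
compound 2, `CO[C@H]1CC[C@@H](CNc2cc(NCc3cnccc3C(F)(F)F)ncc2C#N)CC1`, 70 nM
compound 3, `N#Cc1cnc(NCc2cnccc2C(F)(F)F)cc1N[C@H]1CC[C@@H](C(N)=O)CC1`, 7 nM

Compound 3 gives the lowest number of the three: an 8.3-fold lower number from compound 1 to compound 3 (0.92 log units; beyond the scatter) and a 10-fold lower number from compound 2 to compound 3 (1.00 log units; beyond the scatter) both lie beyond the scatter, whereas a 1.2-fold higher number from compound 1 to compound 2 (0.08 log units; within the scatter) does not. Compound 4, `CC1(C)[C@@H](Nc2cc(NCc3cnccc3C(F)(F)F)ncc2C#N)C[C@H]1C(N)=O`, is not yet measured; it differs from compound 3 by 3-carbamoyl-2,2-dimethylcyclobutyl in place of 4-carbamoylcyclohexyl on a nitrogen on an aromatic ring. The carbamoyl is kept. Among the compounds with values here, of the measured steps, only the two that brought in the carbamoyl bear on this change, and they concern the substituent alone; no measured step alters the ring that carries it, so the move from a six-membered to a four-membered ring with two methyl groups has no precedent in this set. The expectation in this assay is therefore anchored on compound 3 with widened uncertainty: most likely no step beyond the scatter, a loss being somewhat more plausible than a gain. Compound 4 is estimated at 12 nM (range 4 nM to 45 nM). The step expected is a 1.7-fold higher number from compound 3 to compound 4 (0.23 log units; within the scatter).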

Compound 4, half-maximal inhibitory concentration: 140 nM
For compound 4 the middle estimate is 12-fold (1.07 log units) below the measured one; measured number outside the range, above it.
By their numbers in this assay, from the lowest: compound 3; then compounds 1, 2 and 4 (each within the scatter of the next, the first and the last beyond it).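

In this assay the carbamoyl alone does not secure a low number on a nitrogen on an aromatic ring: a 20-fold higher number from compound 3 to compound 4 (1.30 log units; beyond the scatter) comes from changing only the ring that carries it, with the heavy-atom, hydrogen-bond donor and hydrogen-bond acceptor counts of the group unchanged. The benefit of carbamoyl seen on the cyclohexyl does not carry over to the 3-carbamoyl-2,2-dimethylcyclobutyl group, given a 2.4-fold higher number from compound 1 to compound 4 (0.38 log units; beyond the scatter) against the methoxy group and a 2.0-fold higher number from compound 2 to compound 4 (0.30 log units; within the scatter) against the (4-methoxycyclohexyl)methyl group. Nothing available here accounts for this loss.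

Compound 4 changes ring size and adds the two methyl groups at once, so their shares remain unseparated, and a 3-carbamoylcyclobutyl group would address that. Also open, from the compounds shown here alone, is how a carboxylic acid or a primary amine in place of the carbamoyl would read on either ring.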